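Nitrile to Primary Amide on a Bis-Benzimidazole Scaffold

The source may hold more compounds than are shown below. What is called first, only, known or untested is meant among the compounds shown, and "the series" means these compounds.

Compound 2 `N#Cc1ccc2[nH]c(-c3ccc4[nH]c(-c5ccc6ccccc6c5)nc4c3)nc2c1` is the stronger of the two measured compounds: in a functional assay on RPMI 8402 cells (Homo sapiens) for cytotoxicity (a lower number here means a stronger inhibitor, a higher number a weaker inhibitor), compound 2 gives 130 nM, while compound 1 `Cc1ccc(-c2nc3cc(-c4nc5cc(C#N)ccc5[nH]4)ccc3[nH]2)cc1` gives 570 nM. Going by the values given here, the one measured step, a 4.4-fold lower number from compound 1 to compound 2 (0.64 log units; beyond the scatter), concerns a different part of the molecule. Compound 3 `NC(=O)c1ccc2[nH]c(-c3ccc4[nH]c(-c5ccc6ccccc6c5)nc4c3)nc2c1` keeps the naphthalen-2-yl end of compound 2 and differs only in that (carbamoyl in place of cyano on an aromatic carbon), on an aromatic carbon of a six-membered aromatic ring of carbon only, part of a fused system of two rings. No measured step touches this group, so the expectation rests on the change itself rather than on any shown step. A small movement is expected, at or only just beyond the scatter; compound 3 is estimated at 200 nM, in the range 70 nM to 600 nM, which would mean a 1.5-fold higher number from compound 2 to compound 3 (0.19 log units; within the scatter).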

Compound 3, half-maximal inhibitory concentration: 740 nM
Beside the measured number, compound 3's estimate is 3.7-fold (0.57 log units) below it; measured number above the stated range.
By their numbers in this assay, from the lowest: compound 2; then compounds 1 and 3 (each within the scatter of the next).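

Going by these compounds alone, this gives the first measured change at this aromatic carbon of the core: in this assay, carbamoyl in place of cyano gives a 5.7-fold higher number from compound 2 to compound 3 (0.76 log units; beyond the scatter) with the naphthalen-2-yl end held fixed. The position is therefore not indifferent to this exchange, and the added oxygen and hydrogen-bond donor of carbamoyl come with a weaker inhibitor, whereas the earlier step, a 4.4-fold lower number from compound 1 to compound 2 (0.64 log units; beyond the scatter) at the other end of the molecule, said nothing about this site. No measurement shown here bears on the reason for the new step.

Going by these compounds, whether the same exchange would move the number in the same way with the 4-methylphenyl end in place remains open. Also open, on these data alone, is how a carboxylic acid, an amidine or an aminomethyl group would read on this carbon.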